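Methyl at the Ring Carbon on Two Different Cores

A few compounds are considered here, and "the series" means these few. Any claim that something is new, unique, unknown or untested is made for them only; others in the source may bear on it.

Compound 1 `COc1cc(CC(O)(COCc2ccccc2)COCc2ccccc2)nc(OC)n1` and compound 2 `COc1nc(CC(O)(COCc2ccccc2)COCc2ccccc2)c(C)c(OC)n1` share one core; compound 3 `C[Si](C)(C)CCOCn1c(CC(O)CO)cc(=O)[nH]c1=O` and compound 4 `Cc1c(CC(O)CO)n(COCC[Si](C)(C)C)c(=O)[nH]c1=O` share another, and the difference between the two cores is not broken down here. In a functional assay on HepG2 cells (Homo sapiens) for antiproliferative activity, read by MTT assay, with a stated time of 72 h (on this read-out higher numbers stand for weaker inhibition and lower numbers for stronger inhibition), compound 1 gives only a limit, > 100000 nM. Compound 2 gives 2400 nM in this assay, so an at least 41-fold lower number from compound 1 to compound 2 (1.61 log units; beyond the scatter); the change is methyl in place of hydrogen on an aromatic carbon, and the limit of > 100000 nM in this assay, at which 2 of the 3 values shown sit, holds for compound 1. Compound 3 also gives only a limit in this assay, > 100000 nM. Compound 4 carries the same kind of change, (methyl in place of hydrogen on an aromatic carbon), but at a different place: ortho to a 2,3-dihydroxypropyl group and meta to a group of 8 heavy atoms, rather than ortho to a large group and to a methoxy group. Some gain is expected for compound 4, an at least 2.0-fold lower number from compound 3 to compound 4 (0.30 log units; that floor lies within the scatter), because the earlier step was an at least 41-fold lower number from compound 1 to compound 2 (1.61 log units; beyond the scatter). The estimate for compound 4 in this assay is 50000 nM, expected between 8000 nM and 200000 nM.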

Compound 4, half-maximal inhibitory concentration: > 100000 nM
Compound 4 ended at the assay's limit (the forecaster's own chance of this, stated with the estimate: 55%); middle value at least 2.0-fold (0.30 log units) from the limit.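

Compound 3 and compound 4 both stand only as limits, so no step between them can be read: the limit of > 100000 nM in this assay, at which 3 of the 4 values shown sit.

As far as these compounds go, whether methyl in place of hydrogen on an aromatic carbon changes the read-out on the core of compound 3 stays open.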